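Amide substituent changes on a shared sulfonamide core

This account rests on a few compounds, and the source may have more. Where it says the series, first, only, none or still open, it means among the compounds named here.

The series keeps one core, shown in compound 1 `O=C(NC1CCN(CC2CC2)C1)c1cc(-c2ccc(NS(=O)(=O)c3cccc(Cl)c3Cl)cc2)nc2[nH]ncc12`, and varies the group on the amide-type nitrogen. In an assay for inhibition of serine/threonine-protein kinase Sgk1 (Homo sapiens), with stated times of 30 min and 60 min, in the presence of a further agent that is not named here (a lower number here means a stronger inhibitor, a higher number a weaker inhibitor), compound 1 gives 1 nM. Compound 2 `CC(C)NC(=O)c1cc(-c2ccc(NS(=O)(=O)c3cccc(Cl)c3Cl)cc2)nc2[nH]ncc12` carries an isopropyl there and in this assay gives 68 nM; the step of a 68-fold higher number from compound 1 to compound 2 (1.83 log units; beyond the scatter) is the one large move in the set. Compound 3 `CN1CC(NC(=O)c2cc(-c3ccc(NS(=O)(=O)c4cccc(Cl)c4Cl)cc3)nc3[nH]ncc23)C1` carries a 1-methylazetidin-3-yl and in this assay reaches only a limit, < 1 nM; this is the limit of the assay and not a number (the limit of < 1 nM in this assay, at which 1 of the 3 values shown sits). Compound 3 therefore stands no higher than compound 1, the step of a number no higher from compound 1 to compound 3 (the limit leaves the size open) leaving its size open, while an at least 68-fold lower number from compound 2 to compound 3 (1.83 log units; beyond the scatter) is large.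

Compound 4 `CN1CCC(CNC(=O)c2cc(-c3ccc(NS(=O)(=O)c4cccc(Cl)c4Cl)cc3)nc3[nH]ncc23)C1` is not yet measured. Its difference from compound 3 is (1-methylpyrrolidin-3-yl)methyl in place of 1-methylazetidin-3-yl on an amide-type nitrogen. The two steps that bear on it are a 68-fold higher number from compound 1 to compound 2 (1.83 log units; beyond the scatter) and an at least 68-fold lower number from compound 2 to compound 3 (1.83 log units; beyond the scatter), both large and both involving loss or gain of a ring bearing a methylated nitrogen; compound 4 keeps such a ring, so a step of that kind is not expected. The ring also changes size, as between compound 1 and compound 3, where the step was not readable. For compound 4 a number close to compound 1 is expected, an at least 2.0-fold higher number from compound 3 to compound 4 (0.30 log units; that floor lies within the scatter). The estimate for compound 4 in this assay is 2 nM, within 0.6 nM to 8 nM.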

Compound 4, half-maximal inhibitory concentration: 14 nM
Compound 4: middle estimate off by 7.0-fold (0.85 log units), on the low side; measured number outside the range, above it.
By their numbers in this assay, from the lowest: compound 1; then compound 4; then compound 2.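

In this assay, keeping a ring with a substituted nitrogen on the amide-type nitrogen does not by itself preserve the low numbers, as shown by an at least 14-fold higher number from compound 3 to compound 4 (1.14 log units; beyond the scatter) and a 14-fold higher number from compound 1 to compound 4 (1.15 log units; beyond the scatter), both large steps that the earlier compounds gave no sign of. Compound 4 keeps only part of the gain over the isopropyl amide, with a 4.9-fold lower number from compound 2 to compound 4 (0.69 log units; beyond the scatter), a modest step, so this position separates (1-methylpyrrolidin-3-yl)methyl from the groups in compound 1 and compound 3 as well as from isopropyl. The first of these steps has only a floor for its size, as the value for compound 3 is a limit of the assay and not a number: the limit of < 1 nM in this assay, at which 1 of the 4 values shown sits.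

Compound 1 and compound 4 differ both in the methylene link to the amide-type nitrogen and in cyclopropylmethyl versus methyl on the ring nitrogen, so which of the two accounts for their gap stays open, and a 1-methylpyrrolidin-3-yl group on the amide-type nitrogen would separate them. Going by these compounds, how a (1-methylazetidin-3-yl)methyl group or an open-chain amine such as 2-(dimethylamino)ethyl would stand at this position also remains open.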